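Trimming One Trifluoromethyl From a Urea Series

A few compounds are considered here, and "the series" means these few. Any claim that something is new, unique, unknown or untested is made for them only; others in the source may bear on it.

Compound 1 `O=C(Nc1cccc(-n2cc(-c3ccncc3)c(-c3ccc(Cl)c(O)c3)n2)c1)Nc1ccc(Cl)c(Cl)c1` in a functional assay on DU-145 cells (Homo sapiens) for inhibition, read by sulforhodamine B assay, with a stated time of 48 h (on this read-out lower numbers stand for stronger inhibition of growth and higher numbers for weaker inhibition of growth), gives > 32500 nM, a limit of the assay rather than a number.
Compound 2 `O=C(Nc1cccc(-n2cc(-c3ccncc3)c(-c3ccc(Cl)c(O)c3)n2)c1)Nc1cc(C(F)(F)F)cc(C(F)(F)F)c1` in this assay gives 5620 nM.
Compound 3 `COc1cc(-c2nn(-c3cccc(NC(=O)Nc4ccc(Cl)c(C(F)(F)F)c4)c3)cc2-c2ccncc2)ccc1Cl` in this assay gives > 32500 nM, again a limit and not a number.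

Three compounds share one core and differ only in the substituted ring at the far end of the urea. Going by the values given here, compound 2 stands alone: it is the only one with a measured number, while the other two sit at the limit of > 32500 nM in this assay, at which 2 of the 3 values shown sit. Among the compounds with values here, nothing among the measured pairs differs in just one place, so no single measured step can be read off.

Compound 4 `O=C(Nc1cccc(-n2cc(-c3ccncc3)c(-c3ccc(Cl)c(O)c3)n2)c1)Nc1cccc(C(F)(F)F)c1` is the next compound to be tested. It differs from compound 2 by hydrogen in place of trifluoromethyl on an aromatic carbon. That change removes part of what sets compound 2 apart from the two compounds that reached only a limit, so a move toward weaker growth inhibition is expected, and by more than the usual scatter. For compound 4 the expected outcome in this assay is 16000 nM, within a range of 5000 nM to 40000 nM, with a fair chance that only a limit is reported. The expected step is a 2.8-fold higher number from compound 2 to compound 4 (0.45 log units; beyond the scatter).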

Compound 4, concentration for total growth inhibition: > 32500 nM
Compound 4 was reported as a limit; the forecaster's own chance of this, stated with the estimate: 40%; middle value at least 2.0-fold (0.30 log units) away from the limit.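

Going by these compounds alone, this is the first comparison here in which two compounds differ in only one place, so the effect of this position can finally be read directly. In this assay, putting hydrogen in place of trifluoromethyl on an aromatic carbon, meta to a trifluoromethyl group, gives an at least 5.7-fold higher number from compound 2 to compound 4 (0.76 log units; beyond the scatter), a step that lies beyond the usual scatter and shows that growth inhibition in this pair is lost when this one group goes, even though the other trifluoromethyl stays in place. Compound 2 therefore remains the only compound with a measured number, while compound 4 joins the others at the assay's limit: the limit of > 32500 nM in this assay, at which 3 of the 4 values shown sit.

Compound 1 and compound 4 are both limits, so the step between them cannot be read, and the compounds shown do not rank the three limit compounds against one another. As far as these compounds go, it remains open whether a different group at this same position, such as methyl, a nitrile, an amine or a carboxylic acid, would keep a measurable value like that of compound 2 or fall to the limit like compound 4.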